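Benzylamino series: from compound 1 to compound 4

A few compounds are considered here, and "the series" means these few. Any claim that something is new, unique, unknown or untested is made for them only; others in the source may bear on it.

Measured so far, all in a functional assay on NCI-H322M cells (Homo sapiens) for inhibition, read by sulforhodamine B assay, with a stated time of 48 h; a higher number here means a weaker inhibitor of growth, a lower number a stronger inhibitor of growth:
- compound 1 (`Nc1cc(N)c2nc(-c3ccccc3)c(NCc3ccc(Cl)c(Cl)c3)nc2c1`) gives 30200 nM.
- compound 2 (`COc1cc(CNc2nc3cc(N)cc(N)c3nc2-c2ccccc2)cc(OC)c1OC`) gives 15800 nM.
- compound 3 (`CCOC(=O)[C@H](CCC(=O)O)NC(=O)c1ccc(Oc2nc3cc(N)cc(N)c3nc2-c2ccccc2)cc1`) gives only a limit of the assay, < 100000 nM.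

Compound 1 holds the highest of the two numbers reported in this assay; the nearest is compound 2, whose number sits within the scatter of that of compound 1, so no order is read between the two. For compound 3 the record is the limit of < 100000 nM in this assay, at which 1 of the 3 values shown sits, a limit and not a number.

Compound 4 (`Nc1cc(N)c2nc(-c3ccccc3)c(NCc3ccc(F)cc3)nc2c1`) is not yet measured. It differs from compound 1 in one place: 4-fluorophenyl in place of 3,4-dichlorophenyl on a saturated chain carbon bound to a nitrogen on an aromatic ring. Within the data shown here, no measured pair in this set shows a change of this kind, so there is no measured step to lean on. The expected step from compound 1 to compound 4 in this assay is therefore set at none beyond the scatter, a 1.2-fold higher number from compound 1 to compound 4 (0.06 log units; within the scatter), with the range kept wide. Compound 4 is estimated at 35000 nM, between 12000 nM and 100000 nM.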

Compound 4, concentration for total growth inhibition: 11500 nM
Compound 4: the middle estimate sits 3.0-fold (0.48 log units) above what was measured; the whole stated range lies above it.
By their numbers in this assay, from the lowest: compounds 4, 2 and 1 (each within the scatter of the next, the first and the last beyond it).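

Placed on a saturated chain carbon bound to a nitrogen on an aromatic ring, the aryl group is now seen to move the number in this assay: 4-fluorophenyl in place of 3,4-dichlorophenyl gives a 2.6-fold lower number from compound 1 to compound 4 (0.42 log units; beyond the scatter). Among these compounds, this is the only one-place change read so far, so it shows that the two chlorines are not needed for growth inhibition at this level, and it sets no trend. No measured property shown here bears on this step, so it stands without an explanation.

On these data alone, whether the lower number follows the loss of chlorine or the arrival of fluorine stays open, and an unsubstituted benzyl group would help separate the two. As far as these compounds go, how far the step carries to a longer chain at this place, or to a carboxylic acid on the ring, also remains open.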